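A Shorter Chain Tried on a Second Core

A few compounds are considered here, and "the series" means these few. Any claim that something is new, unique, unknown or untested is made for them only; others in the source may bear on it.

Compound 1 `C=C(CC)C(=O)c1ccc(OCc2nc(-c3ccc([N+](=O)[O-])cc3)cs2)c(C)c1C` gives 4.4% in an assay on HL-60 cells for inhibition of glutathione S-transferase P (Homo sapiens), read by spectrophotometry, tested at 5 uM; a lower number here means less inhibition, a higher number more inhibition at the concentration tested (going by the name of the read-out).
Compound 2 `C=C(C)C(=O)c1ccc(OCc2nc(-c3ccc([N+](=O)[O-])cc3)cs2)c(C)c1C` gives 17.2% in this assay.
Compound 3 `C=C(CC)C(=O)c1ccc(OCc2nc(-c3ccc([N+](=O)[O-])cc3)cs2)cc1Cl` gives 10.2% in this assay.

Compound 1 and compound 2 share one core and differ in a single place: hydrogen in place of methyl on a saturated chain carbon bound to a double-bonded chain carbon. That change brought a number 12.8 percentage points higher from compound 1 to compound 2 (beyond the scatter), a step that stands outside the usual scatter of this kind of measurement.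

Compound 3 is built on a second core. How this core differs from that of compound 1 is not broken down here. Its value in this assay sits within the scatter of both compound 1 and compound 2, so nothing can be said about an order among these three.

Compound 4 `C=C(C)C(=O)c1ccc(OCc2nc(-c3ccc([N+](=O)[O-])cc3)cs2)cc1Cl` is the still unmeasured partner of compound 3. It carries exactly the change seen between compound 1 and compound 2: hydrogen in place of methyl on a saturated chain carbon bound to a double-bonded chain carbon. Since the place of the change is described in the same words in both pairs, this is the same change made on a second core.

Within the data shown here, the expectation for compound 4 in this assay is a step of a number 10.8 percentage points higher from compound 3 to compound 4 (beyond the scatter), roughly the size of a number 12.8 percentage points higher from compound 1 to compound 2 (beyond the scatter), because a number 12.8 percentage points higher from compound 1 to compound 2 (beyond the scatter) is the only measured instance of this change. Among the measured compounds shown here, the expected value for compound 4 is 21%, with an estimated range from 8% to 34%, the width reflecting that only one earlier instance supports the transfer.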

Compound 4, a percentage reported as inhibition, at one concentration (the size of the read-out at that concentration, not a potency): 86.7%
Compound 4: middle estimate off by 65.7 percentage points, on the low side; measured number above the stated range.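

On the second core, the change from ethyl to methyl brought a number 76.5 percentage points higher from compound 3 to compound 4 (beyond the scatter) in this assay, so the direction seen on the core of compound 1 appeared again. Among these compounds, the direction carried across, but the size of the step did not, and the two cores gave clearly different results for one and the same change: the same change on two cores in this assay, a number 12.8 percentage points higher (beyond the scatter) from compound 1 to compound 2 and a number 76.5 percentage points higher (beyond the scatter) from compound 3 to compound 4, 63.7 percentage points apart, beyond the scatter of two such steps This shows that a step measured on one core can point the right way and still say little about how large the step will be on another core, but with only two pairs it gives no reason for the gap and cannot tell which step a further core would resemble, and since each number comes from a single tested concentration, neither step is a difference in potency.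

The compounds shown leave open what a longer chain such as propyl, a branched one such as isopropyl, or a small ring such as cyclopropyl would do in place of the ethyl or methyl on either core. They also leave open whether the methyl compound on a third core would follow the smaller step or the larger one.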